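Cytotoxicity notes: aryl change on the acylhydrazide cinnamoyl arm

A few compounds are considered here, and "the series" means these few. Any claim that something is new, unique, unknown or untested is made for them only; others in the source may bear on it.

The series shares one core; compound 1 is `COc1cc(NC(C)CCCNC(=O)NNC(=O)/C(C)=C/c2ccccc2)c2ncccc2c1`, compound 2 is `COc1cc(NC(C)CCCNC(=O)NNC(=O)/C=C/c2ccc(Cl)cc2)c2ncccc2c1` and compound 3 is `COc1cc(NC(C)CCCNC(=O)NNC(=O)/C=C/c2ccccc2F)c2ncccc2c1`. In an ADME assay on L6 cells (Rattus norvegicus) for cytotoxicity, read by resazurin assay, with a stated time of 70 h (on this read-out higher numbers stand for weaker inhibition and lower numbers for stronger inhibition), compound 1 gives 36500 nM, compound 2 gives 7300 nM and compound 3 gives 25100 nM. Compound 3 thus stands second highest of the three numbers: the step of a 3.4-fold higher number from compound 2 to compound 3 (0.54 log units; beyond the scatter) is beyond the scatter, while the step of a 1.5-fold lower number from compound 1 to compound 3 (0.16 log units; within the scatter) is within it.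

Compound 4 is `COc1cc(NC(C)CCCNC(=O)NNC(=O)/C=C/c2ccc(C(F)(F)F)cc2)c2ncccc2c1`. Its structural change from compound 3 is 4-(trifluoromethyl)phenyl in place of 2-fluorophenyl on a double-bonded chain carbon bound to a double-bonded chain carbon. Going by the values given here, the one measured step that bears on this change is a 3.4-fold higher number from compound 2 to compound 3 (0.54 log units; beyond the scatter), where a 4-chlorophenyl was exchanged for a 2-fluorophenyl and the number rose by a modest, real amount. Compound 4 returns a group on the ring position of the 4-chlorophenyl, so the expectation is a step of about that size back down, with the number for compound 4 expected to come close to that of compound 2. Among the compounds with values here, no measured pair covers the trifluoromethyl group itself, so the range is kept wide.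

The expected step is a 2.8-fold lower number from compound 3 to compound 4 (0.45 log units; beyond the scatter). Compound 4 is therefore estimated at 9000 nM, within a range from 3500 nM to 25000 nM.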

Compound 4, half-maximal inhibitory concentration: 28300 nM
Beside the measured number, compound 4's estimate is 3.1-fold (0.50 log units) below it; the measured number lies above the stated range.
By their numbers in this assay, from the lowest: compound 2; then compounds 3, 4 and 1 (each within the scatter of the next).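

In this assay, trifluoromethyl in place of chloro on an aromatic carbon gives a 3.9-fold higher number from compound 2 to compound 4 (0.59 log units; beyond the scatter), so among the compounds shown, the lower number goes with the 4-chlorophenyl group itself and not with every group that carries a substituent at that ring position. With 4-(trifluoromethyl)phenyl in place of 2-fluorophenyl, the result is a 1.1-fold higher number from compound 3 to compound 4 (0.05 log units; within the scatter), and the comparison on the carbonyl carbon gives a 1.3-fold lower number from compound 1 to compound 4 (0.11 log units; within the scatter); these three compounds therefore sit together within the scatter, despite their different aryl arms, while compound 2 alone stands apart from each of them by a step beyond the scatter. Nothing available here gives a reason for the separate standing of the chloro compound.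

Still open, as far as these compounds go, is whether the lower number is specific to chloro or would also appear with another group on that aromatic carbon, such as bromo, methoxy or an amine. The compounds shown also leave open how a 4-chlorophenyl group would read when paired with the 1-methyl substitution on the ethenyl chain of compound 1.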